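Benzyl in place of hydrogen on sulfur: expected inhibition

The source may report more compounds than this note shows. Statements on the series, on what has been measured and on what is new or still open speak of the compounds shown alone.

Measured compounds:
compound 1, `CSc1nccc2c1ncn2C1O[C@H](CO)[C@@H](O)[C@H]1O`, 24%
compound 2, `OC[C@H]1OC(n2cnc3c(S)nccc32)[C@H](O)[C@@H]1O`, 6%

Of the compounds shown here, two have been measured in a functional assay (Homo sapiens) for inhibition of Nucleic Acid, tested at 100 uM; a lower number here means less inhibition, a higher number more inhibition at the concentration tested (going by the name of the read-out). Compound 1 carries a methyl on its sulfur and gives 24%. Compound 2 carries a hydrogen on that sulfur instead, and gives 6%, the lower of the two numbers; the step of a number 18 percentage points lower from compound 1 to compound 2 (beyond the scatter) lies beyond the usual scatter, so compound 2 stands clearly under compound 1.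

Compound 3, `OC[C@H]1OC(n2cnc3c(SCc4ccccc4)nccc32)[C@H](O)[C@@H]1O`, has not yet been measured. It differs from compound 2 in one place: benzyl in place of hydrogen on a sulfur, so the sulfanyl group becomes benzylsulfanyl.

Among the measured compounds shown here, only one measured step bears on this change: a number 18 percentage points lower from compound 1 to compound 2 (beyond the scatter), which shows that removing a methyl from the sulfur lowered inhibition modestly. As far as these compounds go, putting a benzyl onto that sulfur goes the other way, and a rise is therefore expected, though whether benzyl behaves like methyl is unknown here. The estimated step is a number 19 percentage points higher from compound 2 to compound 3 (beyond the scatter). Compound 3 is expected to give 25%, between 5% and 50%.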

Compound 3, a percentage reported as inhibition, at one concentration (the size of the read-out at that concentration, not a potency): 30%
Beside the measured number, compound 3's estimate is 5 percentage points below it, within the range that was stated.
By their numbers in this assay, from the lowest: compound 2; then compounds 1 and 3 (each within the scatter of the next).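

In this assay, the sulfur of the shared core now has a second substituent to compare with the free sulfanyl group: the step of a number 24 percentage points higher from compound 2 to compound 3 (beyond the scatter) shows that benzyl, like methyl before it, goes with a reading clearly apart from that of compound 2. Size alone did not cancel this difference, since benzyl brings 7 heavy atoms and a six-membered aromatic ring to the sulfur, yet the step of a number 6 percentage points higher from compound 1 to compound 3 (within the scatter) leaves methyl and benzyl impossible to rank in this assay. These compounds therefore support a simple distinction between hydrogen and either of these two carbon groups on the sulfur, but no trend with group size, and nothing available explains the difference.

As far as these compounds go, it remains open whether a longer chain such as butyl, or a benzyl whose ring carries an amine or a carboxylic acid, would read like methyl and benzyl or move clearly away from them. From the compounds shown here alone, each number also comes from a single tested concentration, so the compounds' potencies remain unknown.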